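The source may report more compounds than this note shows. Statements on the series, on what has been measured and on what is new or still open speak of the compounds shown alone.

Among the compounds with values here, compound 1 `COc1ccc2[nH]cc(C(=O)/C(C#N)=C/C=C(\Cl)c3ccc(OC)c(OC)c3)c2c1` is one of three compounds measured in a functional assay on MCF7 cells (Homo sapiens) for cytotoxicity, read by sulforhodamine B assay, with a stated time of 48 h; on this read-out higher numbers stand for weaker inhibition of growth and lower numbers for stronger inhibition of growth. In this assay compound 1 reaches only the limit of the assay, giving > 100000 nM, which is a limit and not a number. Compound 2 `COc1ccc2[nH]cc(C(=O)/C(C#N)=C/C=C(\Cl)c3ccc(Br)cc3)c2c1` likewise reaches only a limit in this assay, giving > 100000 nM. Compound 3 `COc1cc(/C(Cl)=C/C=C(\C#N)C(=O)c2c[nH]c3ccc(Br)cc23)cc(OC)c1OC` gives a number in this assay, 96500 nM. Within the data shown here, the one step between measured compounds that differ in a single place, a step that the two limits leave unreadable from compound 1 to compound 2, cannot be read in size, since both of its ends are limits; the evidence on the measured steps is therefore confined to the limit of > 100000 nM in this assay, at which 2 of the 3 values shown sit.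

Compound 4 `COc1ccc(/C(Cl)=C/C=C(\C#N)C(=O)c2c[nH]c3ccccc23)cc1OC` differs from compound 1 by hydrogen in place of methoxy on an aromatic carbon. Among the measured compounds shown here, no measured step bears on this change. Since compound 1 itself sits at a limit, the step of a number no higher from compound 1 to compound 4 (the limit leaves the size open) is expected to stay within the scatter, and compound 4 is expected to give 100000 nM in this assay, in the range from 40000 nM to 300000 nM, with a good chance that this assay again reports only a limit for compound 4.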

Compound 4, concentration for total growth inhibition: > 100000 nM
Compound 4: no number, only a limit (the forecaster's own chance of this, stated with the estimate: 60%); the middle value lies on the limit itself.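

In this assay compound 4 gives > 100000 nM, which is a limit and not a number. Compound 1 also sits at a limit, and the step between compound 1 and compound 4 cannot be read in size. The compounds shown leave open what hydrogen in place of methoxy on an aromatic carbon does to growth inhibition, and the evidence remains confined to one point: the limit of > 100000 nM in this assay, at which 3 of the 4 values shown sit.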